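A second methyl on the chain of compound 2

A few compounds are considered here, and "the series" means these few. Any claim that something is new, unique, unknown or untested is made for them only; others in the source may bear on it.

Compound 1 `O=C(CCCCCNc1c(Nc2ccc(C(F)(F)F)cc2)c(=O)c1=O)NO` gives 4500000 nM
Compound 2 `CC(CCCCC(=O)NO)Nc1c(Nc2ccc(C(F)(F)F)cc2)c(=O)c1=O` gives 30000000 nM

Both values come from a physicochemical assay for solubility, read by HPLC, in phosphate buffer, with a stated time of 24 h, at pH 7.4, tested at 100 uM (a higher number here means a more soluble compound, a lower number a less soluble compound), where a single pair of compounds offers little to compare. Of the two, compound 2 holds the higher number, and its gap to compound 1 lies beyond the scatter.

The next compound is compound 3 `CC(C)(CCCCC(=O)NO)Nc1c(Nc2ccc(C(F)(F)F)cc2)c(=O)c1=O`, and it differs from compound 2 as follows: methyl in place of hydrogen on a saturated chain carbon bound to a nitrogen on an aromatic ring and two saturated chain carbons. In words, this is methyl in place of hydrogen on a saturated chain carbon bound to a nitrogen on an aromatic ring and two saturated chain carbons.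

Within the data shown here, only one measured step bears on this change. It is the modest rise of a 6.7-fold higher number from compound 1 to compound 2 (0.82 log units; beyond the scatter), which came with methyl in place of hydrogen on a saturated chain carbon bound to a nitrogen on an aromatic ring and a saturated chain carbon. One step is thin evidence, and nothing shows that a further methyl repeats it, so a smaller rise in the same direction is expected, perhaps not clearly beyond the scatter. The expected change is a 1.7-fold higher number from compound 2 to compound 3 (0.22 log units; within the scatter) in this assay. For compound 3 the estimated value is 50000000 nM (expected range 10000000 nM to 200000000 nM).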

Compound 3, solubility: 36000000 nM
Compound 3: middle estimate off by 1.4-fold (0.14 log units), on the high side, and the stated range covers the measured number.
By their numbers in this assay, from the lowest: compound 1; then compounds 2 and 3 (each within the scatter of the next).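

In this assay, the second methyl on this chain carbon gives a 1.2-fold higher number from compound 2 to compound 3 (0.08 log units; within the scatter), so this measurement cannot tell compound 3 apart from compound 2. The first methyl on this carbon gave a step of another kind (a 6.7-fold higher number from compound 1 to compound 2 (0.82 log units; beyond the scatter)), which means the same swap of hydrogen for methyl lies beyond the scatter once and within it once across these three compounds, something the earlier pair alone could not show. Nothing measured alongside these numbers accounts for the difference between the two steps. 

The compounds shown leave open whether a group larger than methyl on this carbon, such as an ethyl, or an amine on the same carbon, would stay close to compound 2 and compound 3 or move away from them. They also leave open whether the two methyl steps would look the same on a longer chain, since all three compounds share one core and differ only at this carbon.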